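Shortening the Ether Chain: From Compound 2 to Compound 3

The source may hold more compounds than are shown below. What is called first, only, known or untested is meant among the compounds shown, and "the series" means these compounds.

Compound 1 `C=CCc1cc(C(C)=O)c(O)cc1OCC#N`: 2%
Compound 2 `C=CCc1cc(C(C)=O)c(O)cc1OCCCCCCCCCCC#N`: 14%

Both compounds were tested in an assay on isolated protein for binding affinity to leukotriene B4 receptor 1 (Homo sapiens), tested at 1 uM; on this read-out lower numbers stand for less inhibition and higher numbers for more inhibition at the one concentration tested (going by the name of the read-out). Compound 2 gives 14%, the higher of the two numbers, while compound 1 gives 2%, a gap that lies beyond the usual scatter.

Compound 3 `C#CCCCCOc1cc(O)c(C(C)=O)cc1CC=C` differs from compound 2 by ethynyl in place of 6-cyanohexyl on a saturated chain carbon, four bonds along the chain from an oxygen on an aromatic ring. For the measured compounds named here, no step of this kind has been measured, so its size is uncertain. A small downward step is expected, about a number 8 percentage points lower from compound 2 to compound 3 (within the scatter), which may well stay within the scatter. Compound 3 is therefore estimated to give around 6%, most likely between 0% and 16%.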

Compound 3, a percentage reported as inhibition, at one concentration (the size of the read-out at that concentration, not a potency): 29%
Compound 3: middle estimate off by 23 percentage points, on the low side, outside the stated range (above it).
By their numbers in this assay, from the lowest: compound 1; then compound 2; then compound 3.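

In this assay, ethynyl in place of 6-cyanohexyl at this chain end gives a number 15 percentage points higher from compound 2 to compound 3 (beyond the scatter), and pent-4-yn-1-yl in place of cyano gives a number 27 percentage points higher from compound 1 to compound 3 (beyond the scatter). Among these three compounds, the highest number therefore does not come with the longest chain, and a nitrile at the chain end is not needed for it. Nothing available explains why the number rises.

From the compounds shown here alone, the chain length and its end group change together, so their shares stay open. A nitrile on the chain of compound 3 would separate them, and a carboxylic acid at that chain end remains an open question.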